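This account rests on a few compounds, and the source may have more. Where it says the series, first, only, none or still open, it means among the compounds named here.

The three measured compounds share one core and differ only in the group on the saturated chain carbon bound to a carbonyl carbon. For the measured compounds named here, compound 1 `CC(C)[C@H](NC(=O)COc1cccc2ccccc12)C(=O)N[C@@H](CC(=O)O)C(=O)CSc1nc(-c2ccccc2)c(-c2ccccc2)o1` is the first of them. In a functional assay on Jurkat cells (Homo sapiens) for inhibition (a higher number here means a weaker inhibitor, a lower number a stronger inhibitor), compound 1 reaches only the limit > 200000 nM. Compound 2 `CC(C)[C@H](NC(=O)COc1cccc2ccccc12)C(=O)N[C@@H](CC(=O)O)C(=O)CSc1nc[nH]n1` carries a 1H-1,2,4-triazol-3-yl on a sulfur. In this assay compound 2 likewise gives only the limit > 200000 nM. Compound 3 `CC(C)[C@H](NC(=O)COc1cccc2ccccc12)C(=O)N[C@@H](CC(=O)O)C(=O)CSc1nnnn1-c1ccccc1` carries a 1-phenyl-1H-tetrazol-5-yl on that sulfur. In this assay, going by the values given here, compound 3 gives 153000 nM, the only number of the three. Compound 1 and compound 2 sit at the limit of that assay (the limit of > 200000 nM in this assay, at which 2 of the 3 values shown sit). Among the compounds with values here, the sole measured step, an at least 1.3-fold lower number from compound 2 to compound 3 (0.11 log units; that floor lies within the scatter), is a ring swap whose floor lies within the scatter.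

Compound 4 `CC(C)[C@H](NC(=O)COc1cccc2ccccc12)C(=O)N[C@@H](CC(=O)O)C(=O)COc1ccc2ccccc2n1` differs from compound 3 by (quinolin-2-yl)oxy in place of (1-phenyl-1H-tetrazol-5-yl)sulfanyl on a saturated chain carbon bound to a carbonyl carbon. Within the data shown here, only that step from compound 2 to compound 3 bears on this change, and it swapped a ring on a sulfur; here the sulfur itself leaves with the ring, so it offers no direction. Compound 4 is therefore expected close to compound 3, an estimated 1.5-fold lower number from compound 3 to compound 4 (0.18 log units; within the scatter), giving an estimated 100000 nM with a range from 20000 nM to 200000 nM.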

Compound 4, half-maximal inhibitory concentration: > 200000 nM
Compound 4: only a limit was reported; the forecaster's own chance of this, stated with the estimate: 40%; at least 2.0-fold (0.30 log units) between middle value and limit.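

For the compounds shown here, compound 4 is the first case at this position in which the linking sulfur leaves along with its ring, and this change gives an at least 1.3-fold higher number from compound 3 to compound 4 (0.11 log units; that floor lies within the scatter), so it shows no real difference from compound 3. The step between compound 2 and compound 4 cannot be read, as both values are limits. An oxygen-linked quinolin-2-yl group therefore joins the sulfur-linked rings of compound 1 and compound 2 at the limit, and in this assay compound 3 remains the only one with a number: the limit of > 200000 nM in this assay, at which 3 of the 4 values shown sit.

The compounds shown leave open how the linking atom and the ring each contribute, as the step from compound 3 changes both at once. They also leave open what a plain phenoxy group or an amine on this carbon would give.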